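Methoxy removal on the anilino ring of compound 2

The source may report more compounds than this note shows. Statements on the series, on what has been measured and on what is new or still open speak of the compounds shown alone.

Measured so far:
compound 1 `COc1ccc(C(=O)c2sc(Nc3ccc(Cl)cc3)nc2N)cc1` gives > 10000 nM
compound 2 `COc1ccc(Nc2nc(N)c(C(=O)c3ccccc3OC)s2)cc1` gives 18 nM
compound 3 `COc1ccc(Nc2nc(N)c(C(=O)c3ccccc3)s2)cc1` gives 230 nM

In a functional assay on MOLT-4 cells (Homo sapiens) for antiproliferative activity, read by cell counting, with a stated time of 2 days (on this read-out higher numbers stand for weaker inhibition and lower numbers for stronger inhibition), compound 2 stands lowest of the two numbers shown, the only other number lying a 13-fold higher number from compound 2 to compound 3 (1.11 log units; beyond the scatter). For compound 1 the value given is a limit of the assay, not a number. Compound 4 `COc1ccccc1C(=O)c1sc(Nc2ccccc2)nc1N` differs from compound 2 by hydrogen in place of methoxy on an aromatic carbon. Going by the values given here, the only measured step of the same kind, methoxy to hydrogen at a different place, was a 13-fold higher number from compound 2 to compound 3 (1.11 log units; beyond the scatter), a large loss. Compound 1, which carries a chloro rather than a methoxy, offers only a limit of > 10000 nM in this assay, at which 1 of the 3 values shown sits, and cannot size the change. A loss beyond the scatter is therefore expected for compound 4, though not necessarily as large. Compound 4 is estimated at 100 nM, range 25 nM to 400 nM. The expected step is a 5.6-fold higher number from compound 2 to compound 4 (0.74 log units; beyond the scatter).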

Compound 4, half-maximal inhibitory concentration: 1300 nM
For compound 4 the middle estimate is 13-fold (1.11 log units) below the measured one; measured number above the stated range.
By their numbers in this assay, from the lowest: compound 2; then compound 3; then compound 4. At a limit, above all of these: compound 1.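

In this assay, the change from 4-methoxyphenyl to phenyl gives (a 72-fold higher number from compound 2 to compound 4 (1.86 log units; beyond the scatter)), so the methoxy para to a large group is a major contributor to the value of compound 2. The other methoxy removal gave (a 13-fold higher number from compound 2 to compound 3 (1.11 log units; beyond the scatter)), so both methoxy groups of compound 2 count, and the step at this position is the larger as printed. Nothing measured here gives a reason for this loss.

Open: whether an ethoxy group, a hydroxyl or an amine at this position would retain the value of compound 2.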